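Estimating a cyanobiaryl analogue from two limits

A few compounds are considered here, and "the series" means these few. Any claim that something is new, unique, unknown or untested is made for them only; others in the source may bear on it.

Measured in a functional assay on NIH3T3 cells (Mus musculus); on this read-out higher numbers stand for an effect only at larger amounts of compound and lower numbers for an effect already at smaller amounts:
- Compound 1 `Cn1cncc1C(OCc1ccc(C#N)cc1-c1ccc(-c2ccccc2)cc1)c1ccc(C#N)cc1`: < 0.1 nM (a limit)
- Compound 2 `Cn1cncc1C(OCc1ccc(C#N)cc1C#Cc1cccc(O)c1)c1ccc(C#N)cc1`: > 0.1 nM (a limit)

Compound 2 stands at > 0.1 nM, which is a limit and not a number. The next compound to be tested is compound 3 `Cn1cncc1C(OCc1ccc(C#N)cc1-c1ccc(C#N)cc1)c1ccc(C#N)cc1`, with the rest of the structure unchanged. The change is 4-cyanophenyl in place of 2-(3-hydroxyphenyl)ethynyl on an aromatic carbon.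

Among the measured compounds shown here, only one measured step bears on this change: a number no lower from compound 1 to compound 2 (the limit leaves the size open). That step put 2-(3-hydroxyphenyl)ethynyl in place of 4-phenylphenyl, and its size cannot be read. The entering 4-cyanophenyl is a substituted phenyl group, as is the 4-phenylphenyl of compound 1, so the change partly reverses that step. For the measured compounds named here, this gives a direction, towards a lower number in this assay, but only weak guidance on size, since the two groups differ and no measured step involves 4-cyanophenyl. The expected change is a step that the limit leaves unreadable from compound 2 to compound 3, a rough estimate. For compound 3 the estimated value is 0.2 nM, with an expected range of 0.03 nM to 2 nM.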

Compound 3, half-maximal effective concentration: < 0.1 nM
Compound 3 ended at the assay's limit; the forecaster's own chance of this, stated with the estimate: 35%; at least 2.0-fold (0.30 log units) between middle value and limit.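

In this assay compound 3 gives < 0.1 nM, which is a limit of the assay and not a number. Putting 4-cyanophenyl in place of 2-(3-hydroxyphenyl)ethynyl gives a number no higher from compound 2 to compound 3 (the limit leaves the size open), so on this aromatic carbon, ortho to a large group and meta to a cyano group, a single substituted phenyl ring is enough to reach the same low side of the limit as the 4-phenylphenyl of compound 1, with a cyano group standing where compound 1 carries its outer phenyl ring. The sizes of these steps cannot be read, because the values rest on limits: the limit of < 0.1 nM in this assay, at which 2 of the 3 values shown sit.

Going by these compounds, how far compound 1 and compound 3 lie past the limit stays open, so no order between the two can be given. Also open, on these data alone, is how this assay would read with an amine or a carboxylic acid in place of the cyano group of the 4-cyanophenyl, and whether a plain phenyl ring at this carbon would stay on the same side of the limit.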